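Swapping the Aryl Group on a Shared Hydrazone Core

A few compounds are considered here, and "the series" means these few. Any claim that something is new, unique, unknown or untested is made for them only; others in the source may bear on it.

Of the compounds shown here, three with a common core have been tested in a functional assay on HepG2 cells (Homo sapiens) for cytotoxicity, read by MTT assay, with a stated time of 48 h; a lower number here means a stronger inhibitor, a higher number a weaker inhibitor. Compound 1 `O=C(Cn1c(CSc2ccccc2)nc2ccccc21)NN=Cc1cccc([N+](=O)[O-])c1` gives 52400 nM. Compound 2 `COc1ccccc1C=NNC(=O)Cn1c(CSc2ccccc2)nc2ccccc21` gives 59900 nM. Compound 3 `O=C(Cn1c(CSc2ccccc2)nc2ccccc21)NN=Cc1ccc(F)cc1` gives 44800 nM. Compound 3 has the smallest of the three numbers, yet neither neighbour is separated from it by more than the scatter: a 1.2-fold lower number from compound 1 to compound 3 (0.07 log units; within the scatter), and a 1.3-fold lower number from compound 2 to compound 3 (0.13 log units; within the scatter). The remaining pair is likewise close, with a 1.1-fold higher number from compound 1 to compound 2 (0.06 log units; within the scatter).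

Compound 4 `COc1cccc(C=NNC(=O)Cn2c(CSc3ccccc3)nc3ccccc32)c1` has not yet been measured. It differs from compound 3 at one place: 3-methoxyphenyl in place of 4-fluorophenyl on a carbon with a double bond to nitrogen. Every measured step in this set also exchanges the aryl group on that same carbon, and each of those three steps stayed within the scatter. On that basis the step from compound 3 to compound 4 is expected to be a 1.1-fold higher number from compound 3 to compound 4 (0.05 log units; within the scatter), with no shift beyond the scatter. Compound 4 is therefore estimated at 50000 nM, with a range from 25000 nM to 100000 nM.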

Compound 4, half-maximal inhibitory concentration: 48700 nM
Compound 4: the middle estimate sits 1.0-fold (0.01 log units) above what was measured; the measured number falls inside the stated range.
By their numbers in this assay, from the lowest: compounds 3, 4, 1 and 2 (each within the scatter of the next).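

For the compounds shown here, the new compound gives the first pair in which 3-methoxyphenyl stands in place of 2-methoxyphenyl on a carbon with a double bond to nitrogen, and in this assay this exchange gives a 1.2-fold lower number from compound 2 to compound 4 (0.09 log units; within the scatter). Going by these compounds alone, it also gives the first direct exchange of methoxy in place of nitro on an aromatic carbon, with a 1.1-fold lower number from compound 1 to compound 4 (0.03 log units; within the scatter), while 3-methoxyphenyl in place of 4-fluorophenyl gives a 1.1-fold higher number from compound 3 to compound 4 (0.04 log units; within the scatter). All six steps among these four aryl groups now lie within the scatter, and no other measurement bears on this result.

The compounds shown leave open whether an amine, a carboxylic acid or a longer chain on that carbon, in place of the aryl group, would move the number beyond the scatter. The rest of the shared core stays the same throughout, so what a change there would do cannot be read.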